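This account rests on a few compounds, and the source may have more. Where it says the series, first, only, none or still open, it means among the compounds named here.

Compound 1 `CCC(=O)Nc1ncc(-c2ccc(OC)cc2)n1C` is tested in a toxicity assay on THP-1 cells (Homo sapiens) for inhibition (a lower number here means that less compound is tolerated, a higher number that more compound is tolerated), and gives > 100000 nM, which is a limit of the measurement rather than a number. Compound 2 `Cc1ccccc1-c1cnc(NC(=O)c2ccc(F)cc2)n1C` also reaches only a limit in this assay, at > 50000 nM. Compound 1 therefore stands at a limit, as does the other value shown. Compound 3 `COc1ccc(-c2cnc(NC(=O)c3cccc(OC)c3)n2C)cc1` differs from compound 1 by 3-methoxyphenyl in place of ethyl on a carbonyl carbon. Among the compounds with values here, no step between measured compounds is known, so no direction beyond the scatter can be expected from the data, and compound 3 is expected to show a step of a number no higher from compound 1 to compound 3 (the limit leaves the size open). Compound 3 is estimated at 100000 nM, between 30000 nM and 300000 nM.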

Compound 3, half-maximal cytotoxic concentration: > 100000 nM
Compound 3 gave a limit, no number; the forecaster's own chance of this, stated with the estimate: 75%; the middle value lies on the limit itself.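

Within the data shown here, compound 1 and compound 3 both reach only a limit in this assay, so no step between them can be read: the limit of > 100000 nM in this assay, at which 2 of the 3 values shown sit. The compounds shown leave open whether 3-methoxyphenyl in place of ethyl on a carbonyl carbon changes the tolerated concentration at all.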